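A Benzyl Triazole Variant in an Antiproliferative Series

The compounds below may be only part of what the source reports. "The series", "measured", "known", "first", "only" and "open" are said of these compounds alone.

Measured compounds:
compound 1, `O=C1O/C(=C\Cn2cc(C3=CCCCC3)nn2)C(OCc2ccccc2)=C1OCc1ccccc1`: 55600 nM
compound 2, `O=C1O/C(=C\Cn2cc(-c3ccccc3)nn2)C(OCc2ccccc2)=C1OCc1ccccc1`: > 100000 nM

Going by the values given here, in a functional assay on PC-3 cells (Homo sapiens) for antiproliferative activity, read by MTT assay, with a stated time of 24 h (a lower number here means a stronger inhibitor, a higher number a weaker inhibitor), compound 1 gives 55600 nM and holds the only numerical value shown. In this assay compound 2 gives > 100000 nM, which is a limit of the assay and not a number. Compound 2 therefore sits at the limit of > 100000 nM in this assay, at which 1 of the 2 values shown sits.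

Among the compounds with values here, the one measured step, an at least 1.7-fold higher number from compound 1 to compound 2 (0.25 log units; that floor lies within the scatter), is the sole guide. Its floor lies within the scatter, so the phenyl gave no gain and possibly a loss.

Compound 3, `O=C1O/C(=C\Cn2cc(Cc3ccccc3)nn2)C(OCc2ccccc2)=C1OCc1ccccc1`, differs from compound 1 by benzyl in place of cyclohex-1-en-1-yl on an aromatic carbon. The benzyl shares the aromatic ring of compound 2 but adds one carbon beyond it, so the change is judged against the step to compound 2. Compound 3 is expected to give a number no better than compound 1, with the chance of a limit kept in mind. Its estimated step is a 1.3-fold higher number from compound 1 to compound 3 (0.13 log units; within the scatter). Compound 3 is estimated at 75000 nM, within 30000 nM to 180000 nM.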

Compound 3, half-maximal inhibitory concentration: 71300 nM
Compound 3: middle estimate off by 1.1-fold (0.02 log units), on the high side; measured number inside the range.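

In this assay, benzyl in place of cyclohex-1-en-1-yl on this aromatic carbon gives a 1.3-fold higher number from compound 1 to compound 3 (0.11 log units; within the scatter), so the two groups cannot be told apart at this position, even though one carries an aromatic ring and the other a non-aromatic ring. Compound 3 shares its six-membered aromatic ring with compound 2, and the change from phenyl to benzyl reads an at least 1.4-fold lower number from compound 2 to compound 3 (0.14 log units; that floor lies within the scatter), so the extra carbon cannot be shown to matter, although the aromatic ring alone does not hold a compound at the limit of the assay. Compound 2 stays a limit and not a number: the limit of > 100000 nM in this assay, at which 1 of the 3 values shown sits.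

Whether any group at this position can bring the number far below those of compound 1 and compound 3 remains open, since the three groups shown are all hydrocarbons and an amine, a carboxylic acid or a longer alkyl chain could behave differently. Also open, on these data alone, is whether a fully saturated cyclohexyl or a benzyl ring bearing a fluorine or a methoxy group would separate from the benzyl of compound 3.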